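Para substituent change on the styryl phenyl of compound 3

The source may report more compounds than this note shows. Statements on the series, on what has been measured and on what is new or still open speak of the compounds shown alone.

Working notes on the series. Compound 1 `COc1cc(OC)c2c(=O)cc(/C=C/c3ccccc3)oc2c1` gives 21500 nM in a functional assay on A549 cells (Homo sapiens) for antiproliferative activity, read by MTT assay, with a stated time of 12 h; a higher number here means a weaker inhibitor, a lower number a stronger inhibitor. Compound 2 `COc1cc(OC)c2c(=O)cc(/C=C/c3ccc(C(F)(F)F)cc3)oc2c1` reaches only a limit of this assay, reported as > 40000 nM. Compound 3 `COc1ccc(/C=C/c2cc(=O)c3c(OC)cc(OC)cc3o2)cc1` likewise sits at a limit of this assay, reported as > 40000 nM. That limit is where compound 3 stands on the numbers shown; the step of an at least 1.8-fold higher number from compound 1 to compound 3 (0.26 log units; that floor lies within the scatter) therefore reads only as a floor. Two of the three values share this limit (the limit of > 40000 nM in this assay, at which 2 of the 3 values shown sit).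

Compound 4 `COc1cc(OC)c2c(=O)cc(/C=C/c3ccc(Br)cc3)oc2c1` differs from compound 3 by bromo in place of methoxy on an aromatic carbon. Within the data shown here, no measured step swaps methoxy for bromo. Among the measured compounds shown here, the steps that bear on it are an at least 1.8-fold higher number from compound 1 to compound 3 (0.26 log units; that floor lies within the scatter) and an at least 1.8-fold higher number from compound 1 to compound 2 (0.26 log units; that floor lies within the scatter), both floors; the step that the two limits leave unreadable from compound 2 to compound 3 gives nothing readable. Since compound 3 itself gives only a limit, the step of an at least 1.1-fold lower number from compound 3 to compound 4 (0.05 log units; that floor lies within the scatter) is expected to stay within the scatter, with a weak result for compound 4 in this assay. Compound 4 is estimated at 35000 nM, in the range 12000 nM to 100000 nM, with a fair chance that only a limit is reported.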

Compound 4, half-maximal inhibitory concentration: > 40000 nM
Compound 4: a limit, no number; the forecaster's own chance of this, stated with the estimate: 55%; at least 1.1-fold (0.05 log units) between middle value and limit.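

With bromo on this aromatic carbon, para to a large group, compound 4 also gives only a limit in this assay, so bromo joins trifluoromethyl and methoxy in yielding no number at this place. Among these compounds, the one readable step is an at least 1.8-fold higher number from compound 1 to compound 4 (0.26 log units; that floor lies within the scatter) and it is only a floor; the steps from compound 2 and from compound 3 to compound 4 cannot be read. Compound 1, with hydrogen here, is now the only compound with a number, and the three substituted compounds cannot be told apart: the limit of > 40000 nM in this assay, at which 3 of the 4 values shown sit.

From the compounds shown here alone, whether any of these three substituents truly differs from hydrogen, or from the others, stays open, as every readable floor lies within the scatter. Going by these compounds, how an amine or a carboxylic acid at this place would read in this assay also stays open.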